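The source may hold more compounds than are shown below. What is called first, only, known or untested is meant among the compounds shown, and "the series" means these compounds.

Measured so far in a functional assay on the whole organism with Mus musculus as the target; on this read-out lower numbers stand for an effect already at smaller amounts and higher numbers for an effect only at larger amounts of compound:
- compound 1 `CCCN(c1ccncc1)n1cccc1`: > 20 mg/kg (limit)
- compound 2 `Clc1cccn1Nc1ccncc1`: > 20 mg/kg (limit)
- compound 3 `CCN(c1ccncc1)n1cccc1Cl`: > 20 mg/kg (limit)

Compound 3 stands at > 20 mg/kg, which is a limit of the assay and not a number. Going by the values given here, the series so far offers no numerical reference point: the limit of > 20 mg/kg in this assay, at which 3 of the 3 values shown sit.

Compound 4 `CCCN(c1ccncc1)n1cccc1Cl` is next, and the change is methyl in place of hydrogen on a saturated chain carbon, two bonds along the chain from a nitrogen on an aromatic ring. Cut one bond further out, this reads ethyl to propyl.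

Among the compounds with values here, the one measured step is a step that the two limits leave unreadable from compound 2 to compound 3. It gives no size to carry over, and it concerns a different place on the structure. Compound 1 also carries the propyl chain, and its > 20 mg/kg is likewise a limit.

With no readable step to go on, no change beyond the scatter is expected in this assay, and no direction can be assigned. The expected step is a step that the limit leaves unreadable from compound 3 to compound 4. Compound 4 is most likely to stay at the limit as well. As a number, the estimate for compound 4 is 25 mg/kg, with an expected range of 10 mg/kg to 50 mg/kg.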

Compound 4, dose for half-maximal effect: > 20 mg/kg
Compound 4: a limit, no number; the forecaster's own chance of this, stated with the estimate: 75%; the middle value is on the limit's open side.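

In this assay compound 4 gives > 20 mg/kg as a limit of the assay and not a number. Going by these compounds alone, no step among compound 1, compound 2, compound 3 and compound 4 can be read: the limit of > 20 mg/kg in this assay, at which 4 of the 4 values shown sit. The compounds shown leave open how far each lies from that limit, and whether chloro or ethyl to propyl changes the read-out at all.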